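The source may report more compounds than this note shows. Statements on the series, on what has been measured and on what is new or still open speak of the compounds shown alone.

For the measured compounds named here, compound 3 `COc1cccc(OC)c1OCCNCCOc1ccccc1OCc1cccc(C)c1` gives 8.3 in a functional assay on Vas deferens for antagonist activity at Alpha-1A adrenergic receptor (Rattus norvegicus) (a higher number here means a more potent compound, by a factor of ten per unit of this negative logarithm, a lower number a less potent compound), the lowest of the three numbers so far, though within the scatter of compound 1 `COc1cccc(OC)c1OCCNCCOc1ccccc1OCc1ccccc1` at 8.39 and of compound 2 `COc1cccc(OC)c1OCCNCCOc1ccccc1OCc1ccccc1Cl` at 8.56. The unmeasured compound 4 `COc1cccc(OC)c1OCCNCCOc1ccccc1OCc1cccc([N+](=O)[O-])c1` differs from compound 3 by nitro in place of methyl on an aromatic carbon. The steps that bear on a change at this ring are a number 0.17 log units higher from compound 1 to compound 2 (within the scatter), a number 0.09 log units lower from compound 1 to compound 3 (within the scatter) and a number 0.26 log units lower from compound 2 to compound 3 (within the scatter), each within the scatter; no nitro group has yet been tested anywhere in the series, so nothing shown points to a step beyond the scatter in this assay. Compound 4 is therefore expected to give about 8.3, between 7.8 and 8.8. The estimated step of no change at the digits printed from compound 3 to compound 4 (within the scatter) is expected to stay within the scatter.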

Compound 4, negative logarithm of the antagonist equilibrium constant: 8.85
Compound 4: the middle estimate sits 0.55 log units below what was measured; the whole stated range lies below it.
By their numbers in this assay, from the lowest: compounds 3, 1, 2 and 4 (each within the scatter of the next, the first and the last beyond it).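

Nitro on this ring gives the first steps beyond the scatter in the series in this assay (a number 0.55 log units higher from compound 3 to compound 4 (beyond the scatter); a number 0.46 log units higher from compound 1 to compound 4 (beyond the scatter)), so this position is not flat for every replacement. The 2-chlorophenyl comparison stays within the scatter (a number 0.29 log units higher from compound 2 to compound 4 (within the scatter)), so compound 4 is not separated from compound 2. No measured property bears on the nitro result. Open, as far as these compounds go, is whether an amine, a carboxylic acid or a nitrile at this place on the ring would read like nitro or like methyl, and whether nitro elsewhere on the ring would hold the same number.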